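From 3-cyanopropyl to 2-cyanocyclopropyl

The compounds below may be only part of what the source reports. "The series", "measured", "known", "first", "only" and "open" are said of these compounds alone.

In an ADME assay on MDCKII-LE cells (Canis lupus familiaris) for permeability (on this read-out higher numbers stand for higher permeability and lower numbers for lower permeability), compound 1 (`NC(=O)[C@@H](CCC(F)(F)F)N(CC12CC(c3ncon3)(C1)C2)S(=O)(=O)c1ccc(Cl)cc1`) gives 19.3 10^-6 cm/s, compound 2 (`N#Cc1ccc(CN([C@H](CCC(F)(F)F)C(N)=O)S(=O)(=O)c2ccc(Cl)cc2)cc1`) gives 19.7 10^-6 cm/s and compound 3 (`N#CCCCCN([C@H](CCC(F)(F)F)C(N)=O)S(=O)(=O)c1ccc(Cl)cc1`) gives 24 10^-6 cm/s, so compound 3 stands level with both others within the scatter. Compound 4 (`N#C[C@@H]1C[C@H]1CN([C@H](CCC(F)(F)F)C(N)=O)S(=O)(=O)c1ccc(Cl)cc1`) carries 2-cyanocyclopropyl in place of 3-cyanopropyl on a saturated chain carbon bound to a sulfonamide nitrogen. Three measured steps changed the group at this place, and all stayed within the scatter: a 1.0-fold higher number from compound 1 to compound 2 (0.01 log units; within the scatter), a 1.2-fold higher number from compound 1 to compound 3 (0.09 log units; within the scatter) and a 1.2-fold higher number from compound 2 to compound 3 (0.09 log units; within the scatter). None of them isolates this particular change. Even so, no step beyond the scatter is expected in this assay. The estimated step is a 1.1-fold lower number from compound 3 to compound 4 (0.04 log units; within the scatter). For compound 4 the expected value is 22 10^-6 cm/s, within an estimated range of 13 10^-6 cm/s to 33 10^-6 cm/s.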

Compound 4, apparent permeability: 9.94 10^-6 cm/s
The estimate for compound 4 lay 2.2-fold (0.35 log units) above the measured number; measured number outside the range, below it.
By their numbers in this assay, from the lowest: compounds 4, 1, 2 and 3 (each within the scatter of the next, the first and the last beyond it).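

In this assay, among the compounds shown here, the position proved sensitive to more than the heavy-atom count: 2-cyanocyclopropyl and 3-cyanopropyl have the same count, yet this change produced the first step here beyond the scatter (a 2.4-fold lower number from compound 3 to compound 4 (0.38 log units; beyond the scatter)). Against 4-cyanophenyl and the larger group of compound 1, the change stayed within the scatter (a 2.0-fold lower number from compound 2 to compound 4 (0.30 log units; within the scatter); a 1.9-fold lower number from compound 1 to compound 4 (0.29 log units; within the scatter)). Nothing available here explains the step beyond the scatter. The compounds shown leave open whether it follows from the three-membered ring alone, as a plain cyclopropylmethyl group would test, and whether the two defined stereocentres matter.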